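The source may report more compounds than this note shows. Statements on the series, on what has been measured and on what is new or still open speak of the compounds shown alone.

Measured compounds in an assay on CHO cells for displacement of a labelled ligand from 5-hydroxytryptamine receptor 7 (Homo sapiens), read by scintillation counting, with a stated time of 60 min; a lower number here means a stronger inhibitor, a higher number a weaker inhibitor:
- compound 1, `COc1ccc(/C=C2\NC(=O)N(CCCCN3CCN(c4ccccc4OC)CC3)C2=O)cc1OC`: 16 nM
- compound 2, `COc1ccc(/C=C2\NC(=O)N(CCCCN3CCN(c4ccccc4OC)CC3)C2=O)cc1OC1CCCC1`: 1 nM

Within the data shown here, compound 2 gives the lowest of the two numbers in this assay; its nearest neighbour is compound 1, and the single measured step, a 16-fold lower number from compound 1 to compound 2 (1.20 log units; beyond the scatter), separates them. That step concerns the cyclopentyl in place of methyl on the aromatic oxygen and is beyond the scatter.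

Compound 3, `COc1ccc(/C=C2\NC(=O)N(CCCCN3CCN(c4ncccn4)CC3)C2=O)cc1OC1CCCC1`, keeps that cyclopentyl and differs from compound 2 elsewhere: pyrimidin-2-yl in place of 2-methoxyphenyl on an amine nitrogen in a ring. Among the measured compounds shown here, no measured step touches this position; the only pair on hand changes a different part of the shared core, so nothing here shows the size or direction of the step to compound 3. For the measured compounds named here, with no direct precedent, the expectation for compound 3 is a modest rise, a 5.0-fold higher number from compound 2 to compound 3 (0.70 log units; beyond the scatter), with wide uncertainty. Compound 3 is therefore estimated at 5 nM, within 1 nM to 30 nM.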

Compound 3, inhibition constant: 298 nM
The estimate for compound 3 lay 60-fold (1.78 log units) below the measured number; the measured number lies above the stated range.
By their numbers in this assay, from the lowest: compound 2; then compound 1; then compound 3.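

In this assay, the substituent on the amine nitrogen in a ring proves a strong determinant of the number, a point the earlier pair could not address: pyrimidin-2-yl in place of 2-methoxyphenyl gives a 300-fold higher number from compound 2 to compound 3 (2.47 log units; beyond the scatter). Retaining the cyclopentyl on the aromatic oxygen, which accompanied a 16-fold lower number from compound 1 to compound 2 (1.20 log units; beyond the scatter), does not keep the number low once this change is made. No measurement on hand bears on the cause of the new step.

Still open, as far as these compounds go, is which part of the change carries the step: an unsubstituted phenyl or a pyridin-2-yl on the same nitrogen would separate loss of the methoxy group from introduction of the ring nitrogens. Also open, from the compounds shown here alone, is whether the step keeps its size with methyl rather than cyclopentyl on the aromatic oxygen.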